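From a sec-Butyl Ester to a Cyclobutyl Ester

This account rests on a few compounds, and the source may have more. Where it says the series, first, only, none or still open, it means among the compounds named here.

Compound 1 `CCNC(=O)C1=C(C)NC(=O)NC1c1cccs1` gives 4% in an assay on membranes from HeLa cells for displacement of a labelled ligand from adenosine receptor A3 (Homo sapiens), read by scintillation counting, with a stated time of 180 min, tested at 1 uM; on this read-out lower numbers stand for less inhibition and higher numbers for more inhibition at the one concentration tested (going by the name of the read-out).
Compound 2 `CC1=C(C(=O)OC2CCC2)C(c2ccoc2)NC(=O)N1` gives 1% in this assay.
Compound 3 `CCC(C)OC(=O)C1=C(C)NC(=O)NC1c1cccs1` gives 7% in this assay.

Compound 3 differs from compound 1 and from compound 2 only by amounts within the usual scatter, so the three compounds cannot be ranked. Among the measured compounds shown here, the single measured step, a number 3 percentage points higher from compound 1 to compound 3 (within the scatter), alters the group on the carbonyl carbon and not the ester chain, so it does not speak to the present change. Compound 4 `CC1=C(C(=O)OC2CCC2)C(c2cccs2)NC(=O)N1` differs from compound 3 as follows: cyclobutyl in place of sec-butyl on an oxygen next to a carbonyl group. Compound 2 carries the same cyclobutyl group on a different core and also gives a small number. For the measured compounds named here, no measured step bears directly on this change, so nothing beyond the scatter is expected. Compound 4 is expected to give 5%, with a range from 0% to 15%. The expected step is a number 2 percentage points lower from compound 3 to compound 4 (within the scatter).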

Compound 4, a percentage reported as inhibition, at one concentration (the size of the read-out at that concentration, not a potency): 2%
The estimate for compound 4 lay 3 percentage points above the measured number; the range from low to high includes it.
By their numbers in this assay, from the lowest: compounds 2, 4, 1 and 3 (each within the scatter of the next).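

Cyclobutyl in place of sec-butyl on an oxygen next to a carbonyl group gives a number 5 percentage points lower from compound 3 to compound 4 (within the scatter) in this assay, so this change at this position has no readable effect. The other two new comparisons also show no readable effect: thiophen-2-yl in place of furan-3-yl gives a number 1 percentage points higher from compound 2 to compound 4 (within the scatter), and cyclobutyloxy in place of ethylamino gives a number 2 percentage points lower from compound 1 to compound 4 (within the scatter). No supporting evidence bears on these results.

From the compounds shown here alone, whether a longer chain or an amine at this position would give a number beyond the scatter remains open.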